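Hydrogen in place of methyl on an aromatic carbon

The compounds below may be only part of what the source reports. "The series", "measured", "known", "first", "only" and "open" are said of these compounds alone.

Among the measured compounds shown here, in a physicochemical assay for solubility, read by nephelometry, measured as kinetic solubility, with a stated time of 30 min, at pH 7.4 (on this read-out lower numbers stand for lower solubility and higher numbers for higher solubility), compound 1 `COc1ccc(-n2c(N)nc3ccccc32)c(O)c1` gives 50 ug/mL and compound 2 `Cc1ccc(-n2c(N)nc3ccccc32)c(O)c1` gives 25 ug/mL, so compound 2 stands within the scatter of the only other measured compound. Compound 3 `Nc1nc2ccccc2n1-c1ccccc1O` differs from compound 2 by hydrogen in place of methyl on an aromatic carbon. For the measured compounds named here, the one measured step that bears on this change is a 2.0-fold lower number from compound 1 to compound 2 (0.30 log units; within the scatter), which concerns the same carbon. On that evidence, no step beyond the scatter is expected. The estimated step is a 1.4-fold higher number from compound 2 to compound 3 (0.15 log units; within the scatter). For compound 3 the expected value is 35 ug/mL, with an estimated range of 15 ug/mL to 80 ug/mL.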

Compound 3, solubility: > 100 ug/mL
Compound 3 ended at the assay's limit; the forecaster's own chance of this, stated with the estimate: 10%; middle value at least 2.8-fold (0.45 log units) away from the limit.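

In this assay hydrogen on this carbon, meta to a hydroxy group and para to a large group, gives an at least 4.0-fold higher number from compound 2 to compound 3 (0.60 log units; beyond the scatter) and, set against methoxy, an at least 2.0-fold higher number from compound 1 to compound 3 (0.30 log units; that floor lies within the scatter). Methyl and methoxy at this carbon had shown no step beyond the scatter, so such a step first appears here, with hydrogen. The reading of compound 3 is a limit of the assay and not a number: the limit of > 100 ug/mL in this assay, at which 1 of the 3 values shown sits.

On these data alone, the true size of the step from methyl to hydrogen stays open. So does whether an amine, a fluorine or a carboxylic acid on this carbon would read like hydrogen or like methyl and methoxy.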